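Quinoline chalcone analogues: aryl ketone replacement on MCF7 cells

The compounds below may be only part of what the source reports. "The series", "measured", "known", "first", "only" and "open" are said of these compounds alone.

Measured compounds: compound 1 `COc1ccc(-c2cc3ccccc3nc2/C=C/C(=O)c2ccc(OC)cc2OC)cc1` gives 6260 nM; compound 2 `COc1ccc(-c2cc3ccccc3nc2/C=C/C(=O)c2c(OC)cccc2OC)cc1` gives 4520 nM.

In a functional assay on MCF7 cells (Homo sapiens) for antiproliferative activity, read by XTT assay, with a stated time of 72 h (on this read-out higher numbers stand for weaker inhibition and lower numbers for stronger inhibition), compound 1 holds the highest of the two numbers, the nearest being compound 2, by a 1.4-fold lower number from compound 1 to compound 2 (0.14 log units; within the scatter). Compound 3 `COc1ccc(-c2cc3ccccc3nc2/C=C/C(=O)c2sccc2N)cc1` is not yet measured. The change from compound 1 to compound 3: 3-aminothiophen-2-yl in place of 2,4-dimethoxyphenyl on a carbonyl carbon. No measured step bears on this swap; the only step shown, from one dimethoxyphenyl pattern to another, stayed within the scatter, so no guide to a new ring type exists. A step of modest size or none is expected, estimated at a 1.6-fold lower number from compound 1 to compound 3 (0.19 log units; within the scatter). Compound 3 is thus estimated at 4000 nM, range 1000 nM to 15000 nM.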

Compound 3, half-maximal inhibitory concentration: > 10000 nM
Compound 3: a limit, no number; the forecaster's own chance of this, stated with the estimate: 15%; middle value at least 2.5-fold (0.39 log units) from the limit.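

In this assay, compound 3 gives > 10000 nM, which is a limit of the assay and not a number. This position is not indifferent to ring type: the swap to 3-aminothiophen-2-yl on the carbonyl carbon gives an at least 2.2-fold higher number from compound 2 to compound 3 (0.34 log units; beyond the scatter), while the other step is an at least 1.5-fold higher number from compound 1 to compound 3 (0.20 log units; that floor lies within the scatter).

From the compounds shown here alone, whether the amine or the five-membered ring carries this step stays open, and a plain thiophene ring or an aminophenyl ring would separate the two. The full size of the step also stays open, with only a floor available: the limit of > 10000 nM in this assay, at which 1 of the 3 values shown sits.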